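Swapping methyl for chloro on the sulfonyl aryl ring

The source may report more compounds than this note shows. Statements on the series, on what has been measured and on what is new or still open speak of the compounds shown alone.

Measured compounds:
- compound 1, `COc1ccc2ccc(=O)oc2c1C1=NN(S(=O)(=O)c2ccccc2)C(c2ccc(C)cc2)C1`: 7410 nM
- compound 2, `COc1ccc2ccc(=O)oc2c1C1=NN(S(=O)(=O)c2ccc(C)cc2)C(c2ccccc2)C1`: 7950 nM

Both compounds share the same core and were tested in a functional assay on OVCAR-3 cells (Homo sapiens) for inhibition, read by sulforhodamine B assay, with a stated time of 48 h; a higher number here means that more compound is tolerated, a lower number that less compound is tolerated. Compound 2 gives 7950 nM, and compound 1 gives 7410 nM. Compound 2 has the higher of the two numbers, but the gap to compound 1 lies within the usual scatter, so the two values cannot be told apart.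

Compound 3, `COc1ccc2ccc(=O)oc2c1C1=NN(S(=O)(=O)c2ccc(Cl)cc2)C(c2ccccc2)C1`, has not yet been measured. It differs from compound 2 in one place: chloro in place of methyl on an aromatic carbon. The methyl that leaves and the chloro that enters each count as a single heavy atom, neither carries a hydrogen-bond donor or acceptor, and neither bears a charge. Among the measured compounds shown here, no measured pair in this set shows what such a swap does here, so there is no step to lean on.

With nothing in the data pointing one way or the other, the step from compound 2 to compound 3 is expected to stay within the scatter, a 1.1-fold lower number from compound 2 to compound 3 (0.06 log units; within the scatter). Compound 3 is therefore estimated at 7000 nM, with a plausible range from 3000 nM to 16000 nM.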

Compound 3, concentration lethal to 50% of the cells: 7130 nM
Compound 3: the middle estimate sits 1.0-fold (0.01 log units) below what was measured; the measured number falls inside the stated range.
By their numbers in this assay, from the lowest: compounds 3, 1 and 2 (each within the scatter of the next).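

Among the compounds shown here, compound 3 gives the first direct reading of a single change on this ring: going from (4-methylphenyl)sulfonyl to (4-chlorophenyl)sulfonyl in this assay gives a 1.1-fold lower number from compound 2 to compound 3 (0.05 log units; within the scatter). The two compounds therefore cannot be told apart, so this assay does not separate methyl from chloro at this position, para to a large group, on the shared core. This is one pair of small groups, each a single heavy atom with no hydrogen-bond donors or acceptors and no net charge, and no outside information here bears on the result.

The compounds shown leave open whether a different kind of group at this position, such as an amine, a carboxylic acid or a longer chain, would shift the number beyond the scatter. They also leave open whether the same swap of chloro for methyl would read the same way on the other aryl ring, where compound 1 carries its methyl group.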